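Chloro to Trifluoromethyl on the Benzamide of Compound 2

The compounds below may be only part of what the source reports. "The series", "measured", "known", "first", "only" and "open" are said of these compounds alone.

Compound 2 `O=C(Nc1c(C(O)(C(F)(F)F)C(F)(F)F)ccc2ccccc12)c1ccc(Cl)cc1` gives 570 nM in an assay on LtK cells with ATP-sensitive inward rectifier potassium channel 11 (Homo sapiens) as the target (on this read-out lower numbers stand for an effect already at smaller amounts and higher numbers for an effect only at larger amounts of compound), the higher of the two numbers recorded so far; its nearest neighbour is compound 1 `O=C(Nc1c(C(O)(C(F)(F)F)C(F)(F)F)ccc2ccccc12)c1cccc(Cl)c1`, which gives 98 nM in this assay. Within the data shown here, the one step measured between them, a 5.8-fold higher number from compound 1 to compound 2 (0.76 log units; beyond the scatter), concerns only where the chloro sits on the benzamide ring. Compound 3 `O=C(Nc1c(C(O)(C(F)(F)F)C(F)(F)F)ccc2ccccc12)c1ccc(C(F)(F)F)cc1` differs from compound 2 in another way: trifluoromethyl in place of chloro on an aromatic carbon. Among the measured compounds shown here, no measured step shows what this exchange does here, so the expectation rests on compound 2 alone, with a wide range to allow for either direction. Compound 3 is therefore expected to give about 700 nM in this assay, between 250 nM and 2000 nM, which would mean an expected step of a 1.2-fold higher number from compound 2 to compound 3 (0.09 log units; within the scatter) relative to compound 2, not clearly beyond the scatter.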

Compound 3, half-maximal effective concentration: 160 nM
Compound 3: the middle estimate sits 4.4-fold (0.64 log units) above what was measured; the measured number lies below the stated range.
By their numbers in this assay, from the lowest: compounds 1 and 3 (each within the scatter of the next); then compound 2.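

In this assay the exchange of 4-chlorophenyl for 4-(trifluoromethyl)phenyl gives a 3.6-fold lower number from compound 2 to compound 3 (0.55 log units; beyond the scatter), so at this place the read-out depends on which group is present as well as on where the substituent sits. The comparison with the 3-chlorophenyl compound gives a 1.6-fold higher number from compound 1 to compound 3 (0.21 log units; within the scatter), so the rise of a 5.8-fold higher number from compound 1 to compound 2 (0.76 log units; beyond the scatter) holds for chloro in these compounds and does not extend to trifluoromethyl on the same ring carbon. Nothing available here accounts for the difference between chloro and trifluoromethyl.

On these data alone, it remains open whether trifluoromethyl would also hold its number on the ring carbon that carries chloro in compound 1. Also open, as far as these compounds go, is how a methoxy, a nitrile, an amine or a carboxylic acid would read in place of the trifluoromethyl of compound 3.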